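The compounds below may be only part of what the source reports. "The series", "measured", "known", "first", "only" and "open" are said of these compounds alone.

Measured so far in a functional assay on HCT-116 cells (Homo sapiens) for cytotoxicity, read by MTT assay, with a stated time of 48 h; on this read-out lower numbers stand for stronger inhibition and higher numbers for weaker inhibition:
compound 1 `CCOc1ccc(NC(=O)c2cn(-c3ccccc3)nc2-c2ccc(OC)cc2)cc1`: 970 nM
compound 2 `CCOc1ccc(NC(=O)c2cn(-c3ccccc3)nc2-c2ccc(Cl)cc2)cc1`: 420 nM
compound 3 `COc1ccc(NC(=O)c2cn(-c3ccccc3)nc2-c2ccc([N+](=O)[O-])cc2)cc1`: 1020 nM

Compound 3 gives the highest of the three numbers. Against compound 1 the gap is within the scatter, so no order between those two can be read. Compound 2 sits lower than compound 3, beyond the scatter, but the two differ in two places, so no single step accounts for that gap. Among the measured compounds shown here, the one single-point step measured is a 2.3-fold lower number from compound 1 to compound 2 (0.36 log units; beyond the scatter), which concerns a different substituent altogether.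

Compound 4 `CCOc1ccc(NC(=O)c2cn(-c3ccccc3)nc2-c2ccc([N+](=O)[O-])cc2)cc1` differs from compound 3 by methyl in place of hydrogen on a saturated chain carbon bound to an oxygen on an aromatic ring. For the measured compounds named here, no measured pair isolates this change: compound 1 and compound 2 carry the ethoxy and compound 3 the methoxy, yet each such pairing also differs elsewhere. With nothing bearing directly on the change, the expectation is a step no larger than the scatter, in either direction. Compound 4 is therefore expected at 1000 nM in this assay, with a range of 500 nM to 2000 nM, which amounts to an expected 1.0-fold lower number from compound 3 to compound 4 (0.01 log units; within the scatter).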

Compound 4, half-maximal inhibitory concentration: 390 nM
Compound 4: middle estimate off by 2.6-fold (0.41 log units), on the high side; the measured number lies below the stated range.
By their numbers in this assay, from the lowest: compounds 4 and 2 (each within the scatter of the next); then compounds 1 and 3 (each within the scatter of the next).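

In this assay, the first step measured at this position, methoxy to ethoxy with the nitro group held constant, is a 2.6-fold lower number from compound 3 to compound 4 (0.42 log units; beyond the scatter), so a single added methyl on the saturated chain carbon bound to the oxygen is enough to move the number beyond the scatter. With ethoxy held constant, nitro and chloro cannot be told apart, at a 1.1-fold lower number from compound 2 to compound 4 (0.03 log units; within the scatter), while nitro in place of methoxy gives a 2.5-fold lower number from compound 1 to compound 4 (0.40 log units; beyond the scatter), so compound 1 stands apart from both of the other ethoxy compounds. Nothing at hand bears on the origin of these steps.

From the compounds shown here alone, the methoxy to ethoxy step rests on one pair, so whether it holds with chloro or methoxy as the other substituent remains open. Also open, going by these compounds, is whether a longer chain, such as propoxy, or a branched one, such as isopropoxy, continues the step.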